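Changing the amide substituent of a pyrazolo-fused core

This account rests on a few compounds, and the source may have more. Where it says the series, first, only, none or still open, it means among the compounds named here.

Measured compounds:
- compound 1, `O=C(C1CC1)N1CCCn2nc(COc3ccccc3)cc21`, 61%
- compound 2, `O=C(C1CCC1)N1CCCn2nc(COc3ccccc3)cc21`, 41%
- compound 3, `O=C(C1CCCC1)N1CCCn2nc(COc3ccccc3)cc21`, 41%

In a functional assay on HEK293 cells for positive allosteric modulation of metabotropic glutamate receptor 5 (Homo sapiens), read by calcium flux (a higher number here means a larger maximal response, a lower number a smaller maximal response), compound 1 gives 61%. Compound 2 and compound 3 sit lower: a number 20 percentage points lower from compound 1 to compound 2 (beyond the scatter) and a number 20 percentage points lower from compound 1 to compound 3 (beyond the scatter), while no change at the digits printed from compound 2 to compound 3 (within the scatter). Compound 3 therefore stands level with compound 2, and the two together are the lowest of the three numbers; its only clear gap is to compound 1.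

Compound 4, `O=C(c1ccc(Cl)cc1)N1CCCn2nc(COc3ccccc3)cc21`, differs from compound 3 in one place: 4-chlorophenyl in place of cyclopentyl on a carbonyl carbon. For the measured compounds named here, no measured step swaps a ring of carbon only for an aromatic ring on the carbonyl carbon, so the bearing of the known steps is indirect. The two steps away from cyclopropyl were of modest size and the step from cyclobutyl to cyclopentyl was flat, which suggests that enlarging the group past cyclopropyl has little further effect. The account expects a step of a number 1 percentage points lower from compound 3 to compound 4 (within the scatter), none beyond the scatter, and estimates compound 4 at 40%, with a range from 20% to 65%.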

Compound 4, largest response reached (reported as percent of maximum), in percent of the reference or control that the assay uses: 68%
Compound 4: middle estimate off by 28 percentage points, on the low side, outside the stated range (above it).
By their numbers in this assay, from the lowest: compounds 2 and 3 (each within the scatter of the next); then compounds 1 and 4 (each within the scatter of the next).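

With the first aromatic ring on this carbonyl carbon, this assay shows a number 27 percentage points higher from compound 3 to compound 4 (beyond the scatter) and also a number 27 percentage points higher from compound 2 to compound 4 (beyond the scatter), so moving away from cyclopropyl does not by itself hold the maximal response at the lower level seen with cyclobutyl and cyclopentyl. Measured against cyclopropyl, the same position gives a number 7 percentage points higher from compound 1 to compound 4 (within the scatter), which places the 4-chlorophenyl and cyclopropyl amides together at the upper level of this small series. Nothing available accounts for this recovery of response.

On these data alone, whether the rise belongs to the aromatic ring or to its chlorine stays open, and a plain phenyl group on the same carbonyl carbon would separate the two. Equally open, as far as these compounds go, is how a pyridine ring or an open-chain group such as isopropyl would read in this assay at this position.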